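Replacing butyl(methyl)amino with piperidin-1-yl on the shared core

This account rests on a few compounds, and the source may have more. Where it says the series, first, only, none or still open, it means among the compounds named here.

Among the measured compounds shown here, in a functional assay on CCRF-CEM cells (Homo sapiens) for antiproliferative activity, read by cell counting, with a stated time of 2 days (on this read-out lower numbers stand for stronger inhibition and higher numbers for weaker inhibition), compound 2 (`CCCCN(C)c1nc(N)c(C(=O)c2cc(OC)c(OC)c(OC)c2)s1`) gives 42000 nM and stands highest of the three numbers measured so far. Compound 1 (`COc1cc(C(=O)c2sc(N(C)C)nc2N)cc(OC)c1OC`) reads 11000 nM here, and compound 3 (`COc1cc(C(=O)c2sc(N3CCCC3)nc2N)cc(OC)c1OC`) reads 320 nM here. Compound 4 (`COc1cc(C(=O)c2sc(N3CCCCC3)nc2N)cc(OC)c1OC`) is still unmeasured. It carries piperidin-1-yl in place of butyl(methyl)amino on an aromatic carbon. The closest evidence is compound 3, where pyrrolidin-1-yl replaced the same group and produced a large step (a 130-fold lower number from compound 2 to compound 3 (2.12 log units; beyond the scatter)). Pyrrolidin-1-yl in place of dimethylamino was also large (a 34-fold lower number from compound 1 to compound 3 (1.54 log units; beyond the scatter)), while adding propyl to the open chain moved the number modestly the other way (a 3.8-fold higher number from compound 1 to compound 2 (0.58 log units; beyond the scatter)). No six-membered ring has been measured, so the full size of the step to compound 3 is not assumed to carry over. The step in this assay is expected to be large and smaller than that one, and the estimate is a step toward a lower number (a 21-fold lower number from compound 2 to compound 4 (1.32 log units; beyond the scatter)). Compound 4 is estimated at 2000 nM as its expected value (expected range from 400 nM to 10000 nM).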

Compound 4, half-maximal inhibitory concentration: 22000 nM
The estimate for compound 4 lay 11-fold (1.04 log units) below the measured number, outside the stated range (above it).
By their numbers in this assay, from the lowest: compound 3; then compounds 1, 4 and 2 (each within the scatter of the next, the first and the last beyond it).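

In this assay a saturated ring on this aromatic carbon does not by itself bring the gain seen with compound 3: exchanging pyrrolidin-1-yl for piperidin-1-yl gives a 69-fold higher number from compound 3 to compound 4 (1.84 log units; beyond the scatter) and so separates the two rings widely. Piperidin-1-yl instead stands level with the open-chain amino groups, with a 1.9-fold lower number from compound 2 to compound 4 (0.28 log units; within the scatter) and a 2.0-fold higher number from compound 1 to compound 4 (0.30 log units; within the scatter) both within the scatter, even though compound 1 and compound 2 lie beyond the scatter of each other. Among these four compounds, only pyrrolidin-1-yl stands clearly apart, and compound 3 is the strongest.

On these data alone, it remains open whether the low number needs exactly the five-membered ring, or whether a smaller azetidin-1-yl ring or a morpholin-4-yl ring would also reach it. Nothing given here accounts for the gap between the two rings.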